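The source may report more compounds than this note shows. Statements on the series, on what has been measured and on what is new or still open speak of the compounds shown alone.

Measured compounds:
Compound 1, `C=C(CC)C(=O)c1ccc(OCc2nc(-c3ccc(C(F)(F)F)cc3)cs2)cc1Cl`: 19.7%
Compound 2, `C=C(CC)C(=O)c1ccc(OCc2nc(-c3ccc([N+](=O)[O-])cc3)cs2)c(Cl)c1Cl`: 8.1%
Compound 3, `C=C(CC)C(=O)c1ccc(OCc2nc(-c3ccc4ccccc4c3)cs2)c(Cl)c1Cl`: 4.3%

In an assay on HL-60 cells for inhibition of glutathione S-transferase P (Homo sapiens), read by spectrophotometry, tested at 5 uM (on this read-out higher numbers stand for more inhibition at the one concentration tested (going by the name of the read-out) and lower numbers for less inhibition), compound 3 gives the lowest of the three numbers shown, though its nearest neighbour, compound 2, sits within the scatter of it, and only compound 1 lies beyond the scatter above it. The one measured step that changes a single group, a number 3.8 percentage points lower from compound 2 to compound 3 (within the scatter), is itself within the scatter, so the aromatic group on the five-membered ring has so far shown no effect that can be separated from noise.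

Compound 4, `C=C(CC)C(=O)c1ccc(OCc2nc(-c3ccc(C(F)(F)F)cc3)cs2)c(Cl)c1Cl`, has not yet been measured. It differs from compound 3 in one place: 4-(trifluoromethyl)phenyl in place of naphthalen-2-yl on an aromatic carbon. Among the measured compounds shown here, the only step bearing on this swap is a number 3.8 percentage points lower from compound 2 to compound 3 (within the scatter), and it gives no reason to expect a step beyond the scatter in this assay. For the measured compounds named here, compound 1 carries the same 4-(trifluoromethyl)phenyl group but differs from compound 4 in another place, so its value is noted but no step to compound 4 is known. For compound 4 the expected step is a number 4.7 percentage points higher from compound 3 to compound 4 (within the scatter). Compound 4 is therefore estimated at 9%, within a range from 0% to 22%.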

Compound 4, a percentage reported as inhibition, at one concentration (the size of the read-out at that concentration, not a potency): 22.2%
Beside the measured number, compound 4's estimate is 13.2 percentage points below it, outside the stated range (above it).
By their numbers in this assay, from the lowest: compounds 3 and 2 (each within the scatter of the next); then compounds 1 and 4 (each within the scatter of the next).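

In this assay, the group on the aromatic carbon of the five-membered ring now has an effect that can be separated from noise: 4-(trifluoromethyl)phenyl in place of naphthalen-2-yl gives a number 17.9 percentage points higher from compound 3 to compound 4 (beyond the scatter). The same holds on the phenyl ring itself, where trifluoromethyl in place of nitro gives a number 14.1 percentage points higher from compound 2 to compound 4 (beyond the scatter), so the gain is modest but is seen against both of the other groups. Chloro in place of hydrogen on an aromatic carbon gives a number 2.5 percentage points higher from compound 1 to compound 4 (within the scatter), so that change shows no effect that can be told from the scatter.

Nothing measured here bears on why 4-(trifluoromethyl)phenyl stands apart from the other two groups. As far as these compounds go, it also remains open how an amine or a carboxylic acid in place of trifluoromethyl would read, and what potency lies behind these readings at a single concentration.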